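Swapping 4-methylbenzyl for 4-chlorobenzyl on a shared core

The source may report more compounds than this note shows. Statements on the series, on what has been measured and on what is new or still open speak of the compounds shown alone.

In an ADME assay on the whole organism (plasma, Rattus norvegicus) for protein binding, using cassette dosing, at a dose of 1 mg/kg (on this read-out lower numbers stand for a smaller free fraction and higher numbers for a larger free fraction), compound 1 (`Cc1ccc(Cn2c(=O)n(CC(C)(C)C(=O)O)c(=O)[nH]/c2=N\c2ccc(OC(C)C)c(Cl)c2)cc1`) gives 0.01 as the second highest of three numbers. Compound 2 (`Cc1cc(/N=c2\[nH]c(=O)n(C[C@H](C)C(=O)O)c(=O)n2Cc2ccc(Cl)cc2)ccc1OC(C)C`) gives 0.02 and this lies within the scatter of compound 1. Compound 3 (`CC(C)Oc1ccc(Nc2nc(=O)n(CCO)c(=O)n2Cc2ccc(Cl)cc2)cc1Cl`) gives 0.001 and this lies under compound 1 by more than the scatter.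

Compound 4 (`CC(C)Oc1ccc(/N=c2\[nH]c(=O)n(CC(C)(C)C(=O)O)c(=O)n2Cc2ccc(Cl)cc2)cc1Cl`) departs from compound 1 by chloro in place of methyl on an aromatic carbon in one place: chloro in place of methyl on an aromatic carbon, para to a large group, which turns 4-methylbenzyl into 4-chlorobenzyl. Going by the values given here, no two measured compounds differ in just one place, so the data hold no direct reading of this swap. Compound 2 carries the 4-chlorobenzyl group at 0.02 and its value gives no sign of a shift from compound 1. Compound 3 also carries that group at 0.001 and goes against any simple reading, though its other side chain differs as well. No step beyond the scatter is therefore expected in this assay for this swap. The estimated change is a 1.3-fold lower number from compound 1 to compound 4 (0.10 log units; within the scatter) and it is expected to stay within the scatter. Compound 4 is expected at 0.008 (estimated range 0.003 to 0.02).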

Compound 4, unbound fraction: 0.003
Beside the measured number, compound 4's estimate is 2.7-fold (0.43 log units) above it; low and high end bracket the measured number.
By their numbers in this assay, from the lowest: compound 3; then compound 4; then compounds 1 and 2 (each within the scatter of the next).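

Going by these compounds alone, compound 4 gives the first direct reading of this swap: with the rest of the molecule unchanged, turning 4-methylbenzyl into 4-chlorobenzyl gives in this assay a 3.3-fold lower number from compound 1 to compound 4 (0.52 log units; beyond the scatter), a modest step but one beyond the scatter. The position on the aromatic carbon para to a large group is therefore not silent in this read-out, since exchanging one heavy atom for another, with no change in the counted hydrogen-bond donors, hydrogen-bond acceptors or net charge, is enough to move the number. Nothing available explains why the unbound fraction moves in this direction.

Going by these compounds, whether a step of this size and direction carries over to the side chains of compound 2 and compound 3 remains open, as this single pair rests on the side chain shared by compound 1 and compound 4. Also open, on these data alone, is how the same aromatic carbon would read with a fluoro, methoxy or trifluoromethyl group in place of the chloro, and so whether the step is particular to chloro or extends to other groups.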